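A Methyl Step Beneath a Cytotoxicity Limit

The source may report more compounds than this note shows. Statements on the series, on what has been measured and on what is new or still open speak of the compounds shown alone.

Compound 1 `CN1C(=O)[C@H](NC(=O)c2n[nH]c(Cc3ccccc3)n2)COc2ncccc21`: > 50000 nM
Compound 2 `Cc1cnc2c(c1)N(C)C(=O)[C@H](NC(=O)c1n[nH]c(Cc3ccccc3)n1)CO2`: > 50000 nM
Compound 3 `CN1C(=S)[C@@H](NC(=O)c2n[nH]c(Cc3ccccc3)n2)COc2ncccc21`: > 50000 nM

In an ADME assay on HT-29 cells (Homo sapiens) for cytotoxicity, read by luminescence and CellTiter-Glo, with a stated time of 10 h (a higher number here means that more compound is tolerated, a lower number that less compound is tolerated), compound 1 gives > 50000 nM, which is a limit of the assay. Compound 2 gives > 50000 nM, also a limit. The change methyl in place of hydrogen on an aromatic carbon therefore gives a step that the two limits leave unreadable from compound 1 to compound 2. Compound 3 gives > 50000 nM, again a limit. How the core of compound 3 differs from the core of compound 1 is not broken down here.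

Compound 4 `Cc1cnc2c(c1)N(C)C(=S)[C@@H](NC(=O)c1n[nH]c(Cc3ccccc3)n1)CO2` has not yet been measured in this assay. It differs from compound 3 by methyl in place of hydrogen on an aromatic carbon, the same change as from compound 1 to compound 2. Because (the limit of > 50000 nM in this assay, at which 3 of the 3 values shown sit), the step from compound 3 to compound 4 is expected to be a step that the limit leaves unreadable from compound 3 to compound 4. Compound 4 is expected to give 60000 nM, with a range from 30000 nM to 150000 nM.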

Compound 4, half-maximal cytotoxic concentration: > 50000 nM
Compound 4 was reported as a limit (the forecaster's own chance of this, stated with the estimate: 85%); the middle value does not contradict the limit.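

Compound 3 and compound 4 both stand at a limit of this assay, so no step can be read between them. The compounds shown leave open the actual cytotoxic concentration of all four and whether the methyl shifts it at all.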